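From Carboxymethyl to Chloro on the Amide Chain

A few compounds are considered here, and "the series" means these few. Any claim that something is new, unique, unknown or untested is made for them only; others in the source may bear on it.

The account concerns two compounds that share a core and differ at the chain attached through the amide. Compound 1 `O=C(O)CCC(=O)Nc1ccc(-c2nc3cc(C(F)(F)F)ccc3[nH]2)cc1` was tested in an ADME assay on MDBK cells (Bos taurus) for cytotoxicity, read by MTT assay, with a stated time of 96 h; on this read-out higher numbers stand for lower toxicity in this test and lower numbers for higher toxicity in this test. In this assay compound 1 reached only the limit of the test, reported as > 100000 nM; that value is a limit and not a number. Accordingly, compound 1 stands at the limit of > 100000 nM in this assay, at which 1 of the 2 values shown sits, and its true position can only be said to lie at or beyond that boundary. Going by the values given here, a second compound from the same study, compound 2 `COc1ccc(-c2nc3cc(Cl)c(Cl)cc3[nH]2)c(N)c1`, gave 6500 nM in this assay, a number rather than a limit; no step between compound 1 and compound 2 is drawn here, and the two structures differ in more than one place.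

Compound 3 `O=C(CCl)Nc1ccc(-c2nc3cc(C(F)(F)F)ccc3[nH]2)cc1` has not yet been measured. It differs from compound 1 by chloro in place of carboxymethyl on a saturated chain carbon bound to a carbonyl carbon. Among the compounds with values here, with compound 1 sitting at a limit, no measured step is available to calibrate this change, so the expectation rests only on the structural difference. The author expects compound 3 to move toward higher toxicity in this assay, a step of an at least 6.6-fold lower number from compound 1 to compound 3 (0.82 log units; beyond the scatter) that should exceed the usual scatter. Compound 3 is estimated at 15000 nM, within a range from 3000 nM to 80000 nM.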

Compound 3, half-maximal cytotoxic concentration: 17000 nM
For compound 3 the middle estimate is 1.1-fold (0.05 log units) below the measured one, and the stated range covers the measured number.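

With compound 3, the position on a saturated chain carbon bound to a carbonyl carbon yields its first readable step: in this assay, chloro in place of carboxymethyl gives an at least 5.8-fold lower number from compound 1 to compound 3 (0.76 log units; beyond the scatter), in the direction of higher toxicity in this test. Going by these compounds alone, earlier, the shared core of compound 1 offered no step at all, and compound 2 differs from it in more than one place, so nothing yet showed that a change at this position alone could move the read-out beyond the usual scatter. Going by these compounds, compound 1 supplies only a limit to this step and not a number, so the true size of the step remains unknown: the limit of > 100000 nM in this assay, at which 1 of the 3 values shown sits.

Within the data shown here, the single change removes carboxymethyl and introduces chloro together, so it remains open whether the shift goes with the loss of the one group or the arrival of the other. On these data alone, how a methyl, a bromo, an amine or a longer chain ending in chloro at this place would read in this assay also stays open, as does whether the same change would give a similar step on another core.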